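Mirror Image of a Weak Inhibitor, Estimated

The source may report more compounds than this note shows. Statements on the series, on what has been measured and on what is new or still open speak of the compounds shown alone.

Compound 1 `O=C1c2ccc(O)c(O)c2O[C@@H](c2cccc(O)c2O)[C@@H]1O` was tested in a functional assay on RAW264.7 cells (Rattus norvegicus) for inhibition, with RAW264.7 (Mus musculus) as the target, read by Griess assay, with stated times of 2 h and 16 h (a higher number here means a weaker inhibitor, a lower number a stronger inhibitor), and, being a limit of the assay rather than a number, compound 1 gives > 100000 nM. Compound 2 `COc1ccc2c(c1O)O[C@@H](c1cccc(O)c1O)[C@H](O)C2=O` gives 88500 nM in this assay. For the measured compounds named here, the one measured step, an at least 1.1-fold lower number from compound 1 to compound 2 (0.05 log units; that floor lies within the scatter), lies within the scatter. Compound 3 `O=C1c2ccc(O)c(O)c2O[C@H](c2cccc(O)c2O)[C@H]1O` differs from compound 1 as follows: the two compounds have the same atoms and bonds and differ only in configuration as drawn: 2 of 2 stereo elements differ (all stereocentres are inverted: mirror images); a stereocentre at a saturated ring carbon is drawn S in compound 1 and R in compound 3; a stereocentre at a saturated ring carbon is drawn S in compound 1 and R in compound 3. Going by the values given here, no measured step concerns an inversion of configuration, and the only measured step was small, so the expected change is a number no higher from compound 1 to compound 3 (the limit leaves the size open), nothing beyond the scatter. Compound 3 is therefore estimated at 100000 nM, within 40000 nM to 250000 nM, and will most likely again be reported only as a limit.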

Compound 3, half-maximal inhibitory concentration: 17000 nM
Compound 3: the middle estimate sits 5.9-fold (0.77 log units) above what was measured; measured number below the stated range.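

Inverting both stereocentres, with no atom or bond changed, gives a clear shift in this assay: an at least 5.8-fold lower number from compound 1 to compound 3 (0.76 log units; beyond the scatter). This change can come only from configuration at these two saturated ring carbons: the fact that compounds 1 and 3 differ only in the configuration as drawn. As far as these compounds go, the full size of the step stays unknown, since compound 1 is held only by a limit: the limit of > 100000 nM in this assay, at which 1 of the 3 values shown sits. Still open, from the compounds shown here alone, is whether inverting just one stereocentre would be enough, and how the core of compound 3 would respond to a methyl on a ring oxygen or to an amine in place of a hydroxyl.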